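Bromo for fluoro on the shared core of compound 1

The source may report more compounds than this note shows. Statements on the series, on what has been measured and on what is new or still open speak of the compounds shown alone.

Within the data shown here, compound 1 `O=c1[nH]c(=O)n([C@H]2C[C@@H]3O[PH](O)(O)OC[C@H]3O2)cc1F` is the only compound with a number in a functional assay on L1210 cells (Mus musculus) for antiproliferative activity (a lower number here means a stronger inhibitor, a higher number a weaker inhibitor), and in this assay compound 1 gives 0.06 ug/mL. Compound 2 `COP1(=O)OC[C@H]2O[C@@H](n3cc(Br)c(=O)[nH]c3=O)C[C@@H]2O1` reaches only a limit of this assay, which for compound 2 is > 100 ug/mL. Compound 3 `O=c1[nH]c(=O)n([C@H]2C[C@@H]3O[PH](O)(O)OC[C@H]3O2)cc1Br` is not yet measured and differs from compound 1 by bromo in place of fluoro on an aromatic carbon. Among the measured compounds shown here, no step between measured compounds is available here, so the size of this change is not known from the data. The step is expected to be a loss of potency beyond the usual scatter, a 33-fold higher number from compound 1 to compound 3 (1.52 log units; beyond the scatter). Compound 3 is estimated at 2 ug/mL, within a range from 0.3 ug/mL to 20 ug/mL.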

Compound 3, concentration for 50% inhibition: 457 ug/mL
Compound 3: the middle estimate sits 230-fold (2.36 log units) below what was measured, outside the stated range (above it).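

In this assay, this position on the shared core proves highly sensitive to the identity of the halogen: bromo in place of fluoro gives a 7600-fold higher number from compound 1 to compound 3 (3.88 log units; beyond the scatter). One heavy atom is exchanged for one, with no change in the hydrogen-bond donor or acceptor count, yet that swap alone produces the step. Compound 2 is held at a limit of the assay rather than a number: the limit of > 100 ug/mL in this assay, at which 1 of the 3 values shown sits.

On these data alone, whether chloro, methyl or an amine on this aromatic carbon would fall between fluoro and bromo remains open. A single pair gives no trend across substituents and cannot show what drives the step.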